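Trifluoromethyl for methoxy on the shared aniline core

The compounds below may be only part of what the source reports. "The series", "measured", "known", "first", "only" and "open" are said of these compounds alone.

Measured so far in an assay for binding affinity to Alpha-1B adrenergic receptor (Homo sapiens), read by radioligand binding; a lower number here means a stronger inhibitor, a higher number a weaker inhibitor:
compound 1, `CSc1ccc(F)cc1NCC1=NCCN1`, gives 40.7 nM
compound 2, `COc1ccc(SC)c(NCC2=NCCN2)c1`, gives 692 nM

For the measured compounds named here, compound 2 gives the higher of the two numbers; its nearest neighbour is compound 1, and the only step between measured compounds runs from that compound to it: a 17-fold higher number from compound 1 to compound 2 (1.23 log units; beyond the scatter).

Compound 3, `CSc1ccc(C(F)(F)F)cc1NCC1=NCCN1`, has not yet been measured. It differs from compound 2 in one place: trifluoromethyl in place of methoxy on an aromatic carbon.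

Going by the values given here, no measured step places a trifluoromethyl group at this position, so the expectation rests only on the fact that the one step bearing on this site, a 17-fold higher number from compound 1 to compound 2 (1.23 log units; beyond the scatter), was large and disfavoured methoxy against a smaller substituent. Removing the methoxy is therefore expected to move the number back toward that of compound 1, though how far a trifluoromethyl group reaches is uncertain. For compound 3 in this assay the expected step is a 4.6-fold lower number from compound 2 to compound 3 (0.66 log units; beyond the scatter). The estimate for compound 3 is 150 nM, with a range from 40 nM to 600 nM.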

Compound 3, inhibition constant: 2040 nM
Compound 3: the middle estimate sits 14-fold (1.13 log units) below what was measured; measured number above the stated range.
By their numbers in this assay, from the lowest: compound 1; then compound 2; then compound 3.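

In this assay, putting trifluoromethyl in place of methoxy on this aromatic carbon, para to a methylsulfanyl group, gives a 2.9-fold higher number from compound 2 to compound 3 (0.47 log units; beyond the scatter), so taking methoxy away does not by itself move the number back towards that of compound 1. Measured against fluoro at the same place, the trifluoromethyl group gives a 50-fold higher number from compound 1 to compound 3 (1.70 log units; beyond the scatter), which makes compound 3 the weakest of the three and sets the order at this position as fluoro, then methoxy, then trifluoromethyl, with every step beyond the usual scatter. Nothing available here accounts for that order, and the three values describe it without explaining it.

From the compounds shown here alone, it remains open how a plain hydrogen, a chloro group, a hydroxyl or an amine would stand at this position, and so whether fluoro marks the best end of the range or only the best of these three groups. Going by these compounds, it also remains open whether the same order would hold if the methylsulfanyl group were replaced by another group, such as an ethyl chain, since all three compounds carry it.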